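The source may hold more compounds than are shown below. What is called first, only, known or untested is meant among the compounds shown, and "the series" means these compounds.

In a physicochemical assay for lipophilicity, read by HPLC, at pH 7.5 (a higher number here means a more lipophilic compound, a lower number a more polar compound), compound 1 `CCOc1ccccc1-c1ccc(-c2nc3cnccc3c(C[C@H](C)C(=O)O)c2C#N)cc1` gives 2.2 and compound 2 `CCOc1ccccc1-c1ccc(-c2nc3cnccc3c(C[C@H](C)C(N)=O)c2C#N)cc1` gives 3, so compound 2 holds the higher of the two numbers. Among the compounds with values here, the only measured step is a number 0.80 log units higher from compound 1 to compound 2 (beyond the scatter), with amino in place of hydroxy on a carbonyl carbon. Compound 3 `CCCCC(Nc1c(C#N)c(-c2ccc(-c3ccccc3OCC)cc2)nc2cnccc12)C(N)=O` departs from compound 2 elsewhere: a group of 9 heavy atoms (6 carbon, 2 nitrogen, 1 oxygen; no ring) in place of a group of 6 heavy atoms (4 carbon, 1 nitrogen, 1 oxygen; no ring), on an aromatic carbon. The 2-carbamoylpropyl group leaves, and the change sits opposite the ring nitrogen, ortho to a cyano group. Within the data shown here, no measured step covers this kind of replacement, so the one available step serves only as a rough guide to scale. The entering group is larger and carries more carbon, so a modest rise of similar size is expected, starting from compound 2 at 3. The expected change is a number 0.60 log units higher from compound 2 to compound 3 (beyond the scatter). For compound 3 the estimated value is 3.6, within an expected range of 3 to 4.2.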

Compound 3, distribution coefficient: 3.6
Compound 3: middle estimate and measured number agree at the digits printed, within the range that was stated.
By their numbers in this assay, from the lowest: compound 1; then compound 2; then compound 3.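

In this assay, the open-chain group entering on this aromatic carbon, ortho to a cyano group and opposite the ring nitrogen, in place of 2-carbamoylpropyl gives a number 0.60 log units higher from compound 2 to compound 3 (beyond the scatter), so the number moves at this position even though both groups end in a primary amide. The number goes up although the entering group counts more hydrogen-bond donors and acceptors than the one leaving, and against the acid the same replacement gives a number 1.40 log units higher from compound 1 to compound 3 (beyond the scatter), the widest gap among the three compounds. Nothing at hand explains why the number changes with this replacement. The compounds shown do not separate the part played by the nitrogen attached to the aromatic carbon from that of the longer chain. On these data alone, how a carboxylic acid in place of the amide on the entering chain would read also remains open.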